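A few compounds are considered here, and "the series" means these few. Any claim that something is new, unique, unknown or untested is made for them only; others in the source may bear on it.

Measured in a functional assay on NCI-H460 cells (Homo sapiens) for antiproliferative activity, with a stated time of 72 h; on this read-out higher numbers stand for weaker inhibition and lower numbers for stronger inhibition:

- compound 1 `COc1ccc(-c2cc([C@@H]3O[C@H](CO)[C@@H](O)[C@H]3O)n3ncnc(N)c23)cc1`: 69300 nM
- compound 2 `Cc1ccccc1-c1cc([C@@H]2O[C@H](CO)[C@@H](O)[C@H]2O)n2ncnc(N)c12`: > 100000 nM (a limit of the assay, not a number)

Compound 2 has no number, only (the limit of > 100000 nM in this assay, at which 1 of the 2 values shown sits). The next compound, compound 3 `Nc1ncnn2c([C@@H]3O[C@H](CO)[C@@H](O)[C@H]3O)cc(/C=C/c3ccccc3)c12`, differs from it by 2-phenylethenyl in place of 2-methylphenyl on an aromatic carbon.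

Within the data shown here, only one measured step bears on this change: an at least 1.4-fold higher number from compound 1 to compound 2 (0.15 log units; that floor lies within the scatter). It also swaps one aromatic group for another, but its floor lies within the scatter and it gives no direction for the new group. Among the measured compounds shown here, compound 1 at 69300 nM holds the only number so far, so weak inhibition is expected to persist in this assay. The expected change is small, and the estimate is an at least 1.4-fold lower number from compound 2 to compound 3 (0.15 log units; that floor lies within the scatter). A reading at the limit remains quite possible. For compound 3 the expected value is 70000 nM, within an estimated range of 20000 nM to 200000 nM.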

Compound 3, half-maximal inhibitory concentration: 3700 nM
Compound 3: middle estimate off by 19-fold (1.28 log units), on the high side; measured number below the stated range.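

In this assay, this position on the five-membered aromatic ring can shift the read-out by a large margin, which the earlier pair did not show. With 2-phenylethenyl in place of either group attached directly through its aromatic ring, the result is an at least 27-fold lower number from compound 2 to compound 3 (1.43 log units; beyond the scatter) and a 19-fold lower number from compound 1 to compound 3 (1.27 log units; beyond the scatter). Compound 2 carries a limit of the assay, not a number: the limit of > 100000 nM in this assay, at which 1 of the 3 values shown sits.

Going by these compounds, whether the double bond outside the aromatic rings matters remains open, and a saturated 2-phenylethyl group at the same position would address that. Also open, on these data alone, is whether the terminal phenyl ring is needed, which a shorter chain such as ethenyl or a small amine there would test.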